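The compounds below may be only part of what the source reports. "The series", "measured", "known", "first", "only" and "open" are said of these compounds alone.

Working notes on the series. Compound 1 `COc1ccc(-c2nc(N)c3nn(-c4ccccc4)cc3n2)cc1` and compound 2 `COc1ccc(-n2cc3nc(-c4cccs4)nc(N)c3n2)cc1` share a core and have both been measured in an assay on CHO cells for displacement of a labelled ligand from adenosine receptor A3 (Homo sapiens), read by scintillation counting, with a stated time of 60 min; on this read-out higher numbers stand for weaker inhibition and lower numbers for stronger inhibition. In this assay compound 1 gives 33 nM. In this assay compound 2 gives 78 nM, the highest of the two numbers recorded so far; the gap to compound 1 lies beyond the usual scatter, so compound 2 is the weaker of the two. Among the compounds with values here, compound 1 and compound 2 differ in two places at once, so their two values show only that the arrangement in compound 1 sits lower than the arrangement in compound 2, not which change carries the difference. Compound 3 `COc1ccc(-c2nc(N)c3nn(-c4ccc(OC)cc4)cc3n2)cc1` has not been measured in this assay. Relative to compound 2 the change is 4-methoxyphenyl in place of thiophen-2-yl on an aromatic carbon. Within the data shown here, no step between measured compounds matches this change alone. Because compound 1, which carries the same 4-methoxyphenyl at the same place, gives 33 nM, compound 3 is expected to come in lower than compound 2, with an expected step of a 2.2-fold lower number from compound 2 to compound 3 (0.35 log units; beyond the scatter) beyond the scatter. The estimate for compound 3 in this assay is 35 nM, with a range from 12 nM to 100 nM.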

Compound 3, inhibition constant: 17 nM
Estimate against measurement, compound 3: 2.1-fold (0.31 log units) above, and the stated range covers the measured number.
By their numbers in this assay, from the lowest: compounds 3 and 1 (each within the scatter of the next); then compound 2.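

In this assay, the exchange of thiophen-2-yl for 4-methoxyphenyl on the aromatic carbon between two ring nitrogen atoms gives a 4.6-fold lower number from compound 2 to compound 3 (0.66 log units; beyond the scatter). Within the data shown here, this is the first reading of this position with nothing else altered, so a difference beyond the scatter can now be tied to this one exchange, which the two-place gap between the earlier compounds could not do. The other step, methoxy in place of hydrogen on an aromatic carbon, gives a 1.9-fold lower number from compound 1 to compound 3 (0.29 log units; within the scatter), so the two compounds on either side of that change cannot be told apart in this read-out.

On these data alone, whether this position tolerates something other than an aromatic ring, such as an amine, a carboxylic acid or a longer alkyl chain, remains open, as does the part played by the methoxy of the 4-methoxyphenyl here, which a plain phenyl at this position would address. Nothing measured on these compounds bears on the reason for either step.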